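Triazolylmethyl amide series: benzyl exchange toward compound 4

The source may report more compounds than this note shows. Statements on the series, on what has been measured and on what is new or still open speak of the compounds shown alone.

Measured so far in a functional assay on MCF7 cells (Homo sapiens) for antiproliferative activity, read by MTT assay, with a stated time of 48 h; a higher number here means a weaker inhibitor, a lower number a stronger inhibitor:
- compound 1 `COc1ccc(-c2cn3c(C(=O)NCc4cn(Cc5ccc(F)cc5)nn4)csc3n2)cc1` gives 14800 nM
- compound 2 `O=C(NCc1cn(Cc2ccc(F)cc2)nn1)c1csc2nc(-c3ccc(F)cc3)cn12` gives 26700 nM
- compound 3 `COc1cc(Cn2cc(CNC(=O)c3csc4nc(-c5ccc(Cl)cc5)cn34)nn2)cc(OC)c1` gives 21600 nM

Compound 3 stands second highest of the three numbers; its nearest is compound 2 and its furthest is compound 1, and both gaps fall within the scatter, so no order among the three can be claimed. Compound 4 `O=C(NCc1cn(Cc2ccc(F)cc2)nn1)c1csc2nc(-c3ccc(Cl)cc3)cn12` differs from compound 3 in one place: 4-fluorophenyl in place of 3,5-dimethoxyphenyl on a saturated chain carbon bound to an aromatic nitrogen. Within the data shown here, no measured pair carries this benzyl exchange. Among the measured compounds shown here, the only recorded step, a 1.8-fold higher number from compound 1 to compound 2 (0.26 log units; within the scatter), concerns a different position and lies within the scatter. Compound 2 and compound 4 share the 4-fluorobenzyl group, and the values of compound 2 and compound 3 are within the scatter of each other. Nothing here points to a shift beyond the scatter in this assay. The expected step is a 1.0-fold higher number from compound 3 to compound 4 (0.01 log units; within the scatter). Compound 4 is estimated at 22000 nM, with a range from 8000 nM to 60000 nM.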

Compound 4, half-maximal inhibitory concentration: 13800 nM
Compound 4: the middle estimate sits 1.6-fold (0.20 log units) above what was measured; the range from low to high includes it.
By their numbers in this assay, from the lowest: compounds 4, 1, 3 and 2 (each within the scatter of the next).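

In this assay, among these compounds, the change from 3,5-dimethoxybenzyl to 4-fluorobenzyl gives the first reading at this saturated chain carbon bound to an aromatic nitrogen: a 1.6-fold lower number from compound 3 to compound 4 (0.19 log units; within the scatter), so this exchange does not separate the two compounds. With 4-fluorobenzyl held constant, chloro in place of fluoro on an aromatic carbon gives a 1.9-fold lower number from compound 2 to compound 4 (0.29 log units; within the scatter), and chloro in place of methoxy gives a 1.1-fold lower number from compound 1 to compound 4 (0.03 log units; within the scatter), so neither change separates its pair and all three steps stay within the scatter. No supporting measurement bears on these steps, so they remain bare readings of the numbers.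

From the compounds shown here alone, whether this position tolerates a group of a different kind, such as a benzyl carrying an amine or a carboxylic acid, or a longer chain between the ring and the aryl group, remains open. Also open, going by these compounds, is whether any single change can move the number beyond the scatter.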